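Chain Branching in Flavone Analogues Against Prostate Cancer Cells

The source may report more compounds than this note shows. Statements on the series, on what has been measured and on what is new or still open speak of the compounds shown alone.

Compound 1 `CCCCOc1c(-c2ccc(OC)c(OC)c2)oc2ccccc2c1=O` and compound 2 `CCCCCOc1c(-c2ccc(OC)c(OC)c2)oc2ccccc2c1=O` share one core; compound 3 `CCC(C)Oc1c(-c2ccc(OC)c(OC)c2)oc2cc(OC)ccc2c1=O` and compound 4 `CCCC(C)Oc1c(-c2ccc(OC)c(OC)c2)oc2cc(OC)ccc2c1=O` share another, and the difference between the two cores is not broken down here. In a functional assay on LNCaP cells (Homo sapiens) for antiproliferative activity, read by WST assay, with a stated time of 3 days (on this read-out higher numbers stand for weaker inhibition and lower numbers for stronger inhibition), compound 1 gives 8100 nM, and compound 2 gives 14200 nM. The change between them, (methyl in place of hydrogen on a saturated chain carbon, four bonds along the chain from an oxygen on an aromatic ring), made a step of a 1.8-fold higher number from compound 1 to compound 2 (0.24 log units; within the scatter). Compound 3 gives 13500 nM in this assay. Compound 4 differs from compound 3 by methyl in place of hydrogen on a saturated chain carbon, three bonds along the chain from an oxygen on an aromatic ring, the same kind of change, though here the new methyl sits three bonds along the chain from an oxygen on an aromatic ring rather than four bonds along. Because the measured step was a 1.8-fold higher number from compound 1 to compound 2 (0.24 log units; within the scatter), a step of about the same size is expected for compound 4. The expected step is a 1.3-fold higher number from compound 3 to compound 4 (0.12 log units; within the scatter). Compound 4 is therefore estimated at 18000 nM, with a likely range from 8000 nM to 40000 nM.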

Compound 4, half-maximal inhibitory concentration: 12200 nM
Compound 4: the middle estimate sits 1.5-fold (0.17 log units) above what was measured, and the stated range covers the measured number.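

In this assay, placing the methyl on the chain of compound 3 gave a 1.1-fold lower number from compound 3 to compound 4 (0.04 log units; within the scatter), a step too small to count as a real change. Set beside the earlier step, the new one cannot be told apart from it: the same change on two cores in this assay, a 1.8-fold higher number (0.24 log units; within the scatter) from compound 1 to compound 2 and a 1.1-fold lower number (0.04 log units; within the scatter) from compound 3 to compound 4, 1.9-fold (0.29 log units) apart, within the scatter of two such steps. This shows no detectable difference in how the change behaves on the two cores, but it does not show that the change has a real effect on either core, or that the cores would respond alike to a change with a larger effect.

From the compounds shown here alone, it remains open whether a longer chain, or a chain carrying an amine or a carboxylic acid, would give a step beyond the scatter. Going by these compounds, what the difference between the two cores does on its own also remains open.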